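Compound 4: A Substituted Phenyl in Place of 4-Fluorophenyl

A few compounds are considered here, and "the series" means these few. Any claim that something is new, unique, unknown or untested is made for them only; others in the source may bear on it.

Measured compounds:
Compound 1 `CN(C)CCn1cnnc1-c1cc(Oc2ccc(NC(=O)N/N=C/c3ccccc3)cc2F)ccn1` gives 2250 nM in a functional assay on U-87MG ATCC cells (Homo sapiens) for cytotoxicity, read by MTT assay, with a stated time of 72 h; a lower number here means a stronger inhibitor, a higher number a weaker inhibitor.
Compound 3 `CN(C)CCn1cnnc1-c1cc(Oc2ccc(NC(=O)N/N=C/c3ccc(F)cc3)cc2F)ccn1` gives 2310 nM in this assay.
Compound 2 `Cn1ncnc1-c1cc(Oc2ccc(NC(=O)N/N=C/c3ccccc3)cc2F)ccn1` reaches only a limit of the assay, > 100000 nM, in this assay.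

Compound 3 holds the highest of the two numbers, with compound 1 within the scatter of it: a 1.0-fold higher number from compound 1 to compound 3 (0.01 log units; within the scatter). Going by the values given here, the only large step recorded lies elsewhere, at the triazole, where an at least 44-fold higher number from compound 1 to compound 2 (1.64 log units; beyond the scatter); (the limit of > 100000 nM in this assay, at which 1 of the 3 values shown sits).

Compound 4 `CN(C)CCn1cnnc1-c1cc(Oc2ccc(NC(=O)N/N=C/c3cc(Br)c(O)c(Br)c3)cc2F)ccn1` differs from compound 3 in the change (3,5-dibromo-4-hydroxyphenyl in place of 4-fluorophenyl on a carbon with a double bond to nitrogen). Among the compounds with values here, the one step at this position, fluoro for hydrogen, was flat, so no step beyond the scatter is expected: a 1.1-fold higher number from compound 3 to compound 4 (0.03 log units; within the scatter). Compound 4 is therefore estimated at 2500 nM, between 700 nM and 9000 nM.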

Compound 4, half-maximal inhibitory concentration: > 100000 nM
Compound 4: only a limit was reported; the forecaster's own chance of this, stated with the estimate: 10%; middle value at least 40-fold (1.60 log units) from the limit.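

Fluoro in place of hydrogen had left the phenyl on the carbon with a double bond to nitrogen flat, but this position does not tolerate every change: in this assay, 3,5-dibromo-4-hydroxyphenyl gives an at least 43-fold higher number from compound 3 to compound 4 (1.63 log units; beyond the scatter), and against the plain phenyl it gives an at least 44-fold higher number from compound 1 to compound 4 (1.64 log units; beyond the scatter). Compound 4 stands at a limit of the assay, as compound 2 does: the limit of > 100000 nM in this assay, at which 2 of the 4 values shown sit.

The compounds shown do not separate the two bromine atoms from the hydroxyl. From the compounds shown here alone, a phenyl carrying only a hydroxyl, only bromine, or a methoxy group in place of the hydroxyl remains open.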